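Trading Trifluoromethyl for Methoxy in a Cytotoxicity Series

A few compounds are considered here, and "the series" means these few. Any claim that something is new, unique, unknown or untested is made for them only; others in the source may bear on it.

Measured so far:
compound 1, `CN(C)CCCNc1nc2cc([N+](=O)[O-])ccc2nc1NCc1ccc(C(F)(F)F)cc1`: 5.66 ug/mL
compound 2, `O=[N+]([O-])c1ccc2nc(NCc3ccc(C(F)(F)F)cc3)c(N3CCCCC3)nc2c1`: > 200 ug/mL

In an ADME assay on HEK293 cells (Homo sapiens) for cytotoxicity, read by MTT assay, with a stated time of 24 h (on this read-out lower numbers stand for stronger inhibition and higher numbers for weaker inhibition), compound 1 gives 5.66 ug/mL, which is the only plain number among the two results shown. Compound 2 reaches only the limit of > 200 ug/mL in this assay, so for compound 2 the assay reports a limit and not a number. That limit is the limit of > 200 ug/mL in this assay, at which 1 of the 2 values shown sits. For the measured compounds named here, the single measured step, an at least 35-fold higher number from compound 1 to compound 2 (1.54 log units; beyond the scatter), arises from piperidin-1-yl in place of (3-(dimethylamino)propyl)amino on an aromatic carbon of the shared core.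

Compound 3, `COc1ccc(CNc2nc3ccc([N+](=O)[O-])cc3nc2NCCCN(C)C)cc1`, keeps the (3-(dimethylamino)propyl)amino group of compound 1 and differs from it elsewhere: methoxy in place of trifluoromethyl on an aromatic carbon. Going by the values given here, no measured step touches this part of the molecule, so the only comparison available, the step from compound 1 to compound 2, does not bear on this change. With nothing to point either way, the step is expected to fall within the usual scatter. Compound 3 is therefore expected to give about 8 ug/mL in this assay, in the range 2.5 ug/mL to 30 ug/mL. The estimate of a 1.4-fold higher number from compound 1 to compound 3 (0.15 log units; within the scatter) is expected to stay within the scatter.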

Compound 3, half-maximal inhibitory concentration: 38.6 ug/mL
Compound 3: middle estimate off by 4.8-fold (0.68 log units), on the low side; the measured number lies above the stated range.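

Until now, the only change shown was at the (3-(dimethylamino)propyl)amino group. This result shows that the other end of the molecule also matters in this assay: going from 4-(trifluoromethyl)phenyl to 4-methoxyphenyl, with the (3-(dimethylamino)propyl)amino group left in place, gives a 6.8-fold higher number from compound 1 to compound 3 (0.83 log units; beyond the scatter), so compound 3 is the weaker inhibitor of this pair on this read-out. The change is still smaller than the one at the other site, an at least 35-fold higher number from compound 1 to compound 2 (1.54 log units; beyond the scatter), a step that ends at a limit of the assay and not at a plain number, and nothing measured here explains why swapping trifluoromethyl for methoxy moves the number.

Going by these compounds, two groups at one position cannot show how the number responds to this site in general, so it remains open whether a chlorine atom, a nitrile or a plain hydrogen on that aromatic carbon would read closer to compound 1 or to compound 3. On these data alone, it is also open whether methoxy would have a similar effect on a compound carrying piperidin-1-yl or a longer amine chain instead of the (3-(dimethylamino)propyl)amino group.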